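Notes: sulfonyl aryl change, compound 3 to compound 4

The source may report more compounds than this note shows. Statements on the series, on what has been measured and on what is new or still open speak of the compounds shown alone.

Measured so far in a functional assay on HepG2 cells (Homo sapiens) for antiproliferative activity, read by MTT assay, with a stated time of 24 h (a lower number here means a stronger inhibitor, a higher number a weaker inhibitor), as half-maximal inhibitory concentration:
- compound 1 `Cc1ccc(-c2nn(-c3ccccc3)cc2-c2nc3ccccc3n2S(=O)(=O)c2cc(C)ccc2C)cc1` gives 460 nM
- compound 2 `Cc1ccc(-c2nn(-c3ccccc3)cc2-c2nc3ccccc3n2S(=O)(=O)c2ccc(Br)cc2)cc1` gives 3040 nM
- compound 3 `Cc1ccc(C)c(S(=O)(=O)n2c(-c3cn(-c4ccccc4)nc3-c3ccc(F)cc3)nc3ccccc32)c1` gives 410 nM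

Compound 3 at 410 nM sits with compound 1, as a 1.1-fold lower number from compound 1 to compound 3 (0.05 log units; within the scatter) shows; that step is fluoro in place of methyl on an aromatic carbon. Compound 2 at 3040 nM has a clearly higher number than both.

Compound 4 `O=S(=O)(c1ccc(Cl)cc1)n1c(-c2cn(-c3ccccc3)nc2-c2ccc(F)cc2)nc2ccccc21` is not yet measured. The change is 4-chlorophenyl in place of 2,5-dimethylphenyl on a sulfonyl sulfur and it is made on a sulfonyl sulfur whose other neighbour is an aromatic nitrogen.

The closest measured precedent is a 6.6-fold higher number from compound 1 to compound 2 (0.82 log units; beyond the scatter) with 4-bromophenyl in place of 2,5-dimethylphenyl on a sulfonyl sulfur. This modest step rests on one pair only, and 4-chlorophenyl itself has not been measured in this series. The fluoro step above gives no reason to expect a different outcome on compound 3, so a rise of similar or slightly smaller size is expected in this assay and would lie beyond the scatter. The expected step is a 5.4-fold higher number from compound 3 to compound 4 (0.73 log units; beyond the scatter) on this reasoning. For compound 4 the estimate is 2200 nM with an expected range from 900 nM to 5000 nM as working bounds.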

Compound 4, half-maximal inhibitory concentration: 4230 nM
Compound 4: the middle estimate sits 1.9-fold (0.28 log units) below what was measured; the measured number falls inside the stated range.
By their numbers in this assay, from the lowest: compounds 3 and 1 (each within the scatter of the next); then compounds 2 and 4 (each within the scatter of the next).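

In this assay, the exchange of 2,5-dimethylphenyl for a 4-halophenyl on the sulfonyl sulfur now has a second pair behind it, with a 10-fold higher number from compound 3 to compound 4 (1.01 log units; beyond the scatter) (large) alongside a 6.6-fold higher number from compound 1 to compound 2 (0.82 log units; beyond the scatter), and both steps lie beyond the scatter. The earlier compounds shown here showed this rise only with 4-bromophenyl and only on the core of compound 1, whereas it now also appears with 4-chlorophenyl on the core of compound 3, and neither pair goes against it, so the sulfonyl aryl group matters on both cores while the fluoro step on the other aryl group stays within the scatter. The data shown hold no measurement that explains why this exchange raises the number.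

The two pairs change the loss of both methyl groups and the arrival of a halogen in a single step, so they leave open which of these goes with the rise. A plain phenyl on the sulfonyl sulfur would help to separate the two, while a methoxy group, an amine or a carboxylic acid on that aryl ring would show whether the position tolerates anything other than methyl and halogen.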